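Ester Pair on a Shared Core, One Ring Substituent Swapped

The source may report more compounds than this note shows. Statements on the series, on what has been measured and on what is new or still open speak of the compounds shown alone.

Measured compounds:
compound 1 `Cc1cc2c(C(C)C)ccc(C)c2cc1OC(=O)c1cccc(C(F)(F)F)c1`: "not active" (no number reported)
compound 2 `CC1=CC[C@H](C(C)C)c2cc(C)c(OC(=O)Nc3ccccc3)cc21`: 92.6%

In a functional assay on K562 cells (Homo sapiens) for antiproliferative activity, read by sulforhodamine B assay, with a stated time of 48 h, tested at 50 uM (on this read-out lower numbers stand for less inhibition and higher numbers for more inhibition at the one concentration tested (going by the name of the read-out)), compound 1 gives "not active" (no number reported), so no single number stands behind it; it is simply reported as inactive. Compound 2, which carries a carbamate rather than an ester and a core that differs in several places at once, gives 92.6% in this assay. No step between these two is shown, and only their two values can be compared, not the change itself.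

Compound 3 `COc1cccc(C(=O)Oc2cc3c(C)ccc(C(C)C)c3cc2C)c1` differs from compound 1 in one place: methoxy in place of trifluoromethyl on an aromatic carbon. For the measured compounds named here, no measured step covers this change. Given that compound 1 has no reported inhibition in this assay, a step of no more than the usual scatter is expected, in either direction, and compound 3 is estimated to reach about 15% in this assay, within a range from 0% to 45%.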

Compound 3, a percentage reported as inhibition, at one concentration (the size of the read-out at that concentration, not a potency): 14.2%
Compound 3: middle estimate off by 0.8 percentage points, on the high side; the measured number falls inside the stated range.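

In this assay, for the compounds shown here, compound 1 gives "not active" (no number reported) and compound 3 gives 14.2%, so no step between compound 1 and compound 3 can be read. The compounds shown leave open how far methoxy in place of trifluoromethyl shifts inhibition. Nothing shown bears on the reason for either result.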